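The compounds below may be only part of what the source reports. "The series", "measured", "known", "first", "only" and "open" are said of these compounds alone.

Compound 1 `Cc1nnsc1CO/N=C/c1c(C)nn(C)c1Oc1ccccc1Cl` gives 42500 nM in a functional assay on HCT-116 cells (Homo sapiens) for inhibition, read by MTT assay, with a stated time of 48 h; on this read-out lower numbers stand for stronger inhibition and higher numbers for weaker inhibition.
Compound 2 `Cc1ccc(Oc2c(/C=N/OCc3snnc3C)c(C)nn2C)cc1` gives 13800 nM in this assay.
Compound 3 `Cc1nnsc1CO/N=C/c1c(C)nn(C)c1Oc1ccccc1OC(F)(F)F` reaches only a limit, > 50000 nM, in this assay.

Compound 1 holds the highest of the two numbers: the step of a 3.1-fold lower number from compound 1 to compound 2 (0.49 log units; beyond the scatter) separates it from compound 2, and the step of an at least 1.1-fold higher number from compound 1 to compound 3 (0.07 log units; that floor lies within the scatter) ends at the limit of > 50000 nM in this assay, at which 1 of the 3 values shown sits. Compound 4 `CCCc1nnsc1CO/N=C/c1c(C)nn(C)c1Oc1ccccc1Cl` differs from compound 1 by ethyl in place of hydrogen on a saturated chain carbon bound to an aromatic carbon. Neither measured step touches that part of the molecule; both alter the aryl ether, one exchanging the whole ring and one its substituent, so neither bears on the 4-propyl-1,2,3-thiadiazol-5-yl group. Lacking a guide, compound 4 is expected to stay near compound 1, with a step of a 1.1-fold lower number from compound 1 to compound 4 (0.03 log units; within the scatter) that lies within the scatter. The estimate for compound 4 is 40000 nM, between 15000 nM and 110000 nM.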

Compound 4, half-maximal inhibitory concentration: 16400 nM
For compound 4 the middle estimate is 2.4-fold (0.39 log units) above the measured one; the measured number falls inside the stated range.
By their numbers in this assay, from the lowest: compounds 2 and 4 (each within the scatter of the next); then compound 1. At a limit, above all of these: compound 3.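

The earlier steps shown here changed only the aryl ether. This result shows that the number in this assay also responds at the saturated chain carbon bound to an aromatic carbon: 4-propyl-1,2,3-thiadiazol-5-yl in place of 4-methyl-1,2,3-thiadiazol-5-yl gives a 2.6-fold lower number from compound 1 to compound 4 (0.41 log units; beyond the scatter), a modest step beyond the scatter. Nothing measured here gives a reason for this step. Going by these compounds, it remains open whether a butyl chain or a cyclopropyl group would extend the step, and whether the propyl group would give a similar step on the 4-methylphenyl ether of compound 2.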